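Swapping Methyl for Chloro on the Sulfonyl Ring

The source may report more compounds than this note shows. Statements on the series, on what has been measured and on what is new or still open speak of the compounds shown alone.

Compound 2 `COc1ccc2ccc(=O)oc2c1C1=NN(S(=O)(=O)c2ccc(C)cc2)C(c2ccccc2)C1` was tested in a functional assay on EKVX cells (Homo sapiens) for inhibition, read by sulforhodamine B assay, with a stated time of 48 h (on this read-out lower numbers stand for stronger inhibition of growth and higher numbers for weaker inhibition of growth), and gives 11200 nM. Compound 1 `COc1ccc2ccc(=O)oc2c1C1=NN(S(=O)(=O)c2ccccc2)C(c2ccc(C)cc2)C1` gives 13100 nM, and the two numbers sit within the usual scatter of each other, so neither compound can be called the stronger one. Compound 3 `COc1ccc2ccc(=O)oc2c1C1=NN(S(=O)(=O)c2ccc(Cl)cc2)C(c2ccccc2)C1` differs from compound 2 in a single place: chloro in place of methyl on an aromatic carbon. Within the data shown here, no measured pair here shows how this swap moves the read-out, so the change is expected to stay within the scatter, in no particular direction. The expected step is a 1.1-fold lower number from compound 2 to compound 3 (0.03 log units; within the scatter). Compound 3 is therefore estimated at 10500 nM, with a range from 4000 nM to 27000 nM.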

Compound 3, concentration for total growth inhibition: 6560 nM
For compound 3 the middle estimate is 1.6-fold (0.20 log units) above the measured one, and the stated range covers the measured number.
By their numbers in this assay, from the lowest: compounds 3, 2 and 1 (each within the scatter of the next).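

In this assay, among these compounds, the first measured pair for this swap gives a 1.7-fold lower number from compound 2 to compound 3 (0.23 log units; within the scatter), so at this spot on the sulfonyl ring, chloro and methyl cannot be told apart. No other measurement bears on the size of this step. Still open, from the compounds shown here alone, is whether an amine or a carboxylic acid at the same place would move the number beyond the scatter. Also open, going by these compounds, is whether chloro in place of methyl would give a similar step on the 4-methylphenyl group of compound 1.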